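Replacing a chlorophenyl by a tert-butyl on the sulfonyl aryl

A few compounds are considered here, and "the series" means these few. Any claim that something is new, unique, unknown or untested is made for them only; others in the source may bear on it.

Compound 1 `CC(=O)Nc1ccc(S(=O)(=O)N2CCC(N3CCC(C)CC3)CC2)c2ccccc12`: 1100 nM
Compound 2 `CC1CCN(C2CCN(S(=O)(=O)c3ccc(-c4ccc(Cl)cc4)cc3)CC2)CC1`: 105 nM
Compound 3 `CC1CCN(C2CCN(S(=O)(=O)c3ccc(Cl)c4ccccc34)CC2)CC1`: 0.1 nM

Of the compounds shown here, three sharing the same piperidinyl-piperidine sulfonamide core have been tested in a functional assay on DLD-1 cells (Homo sapiens) for antiproliferative activity, read by CellTiter-Glo, with a stated time of 72 h; on this read-out higher numbers stand for weaker inhibition and lower numbers for stronger inhibition. Compound 2 stands second highest of the three numbers; its nearest neighbour is compound 1, whose number is higher, while compound 3 lies far lower. Within the data shown here, the one step that is counted between measured compounds, an 11000-fold lower number from compound 1 to compound 3 (4.04 log units; beyond the scatter), concerns a substituent on the bicyclic ring of compound 1 and compound 3 and so does not touch the part changed here.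

Compound 4 `CC1CCN(C2CCN(S(=O)(=O)c3ccc(C(C)(C)C)cc3)CC2)CC1` differs from compound 2 in one place: tert-butyl in place of 4-chlorophenyl on an aromatic carbon. Among the measured compounds shown here, no measured step bears directly on this change, since compound 2 and compound 3 differ in more than one place and their values can only be compared as they stand. The expectation therefore rests on little: the estimated step is a 2.4-fold higher number from compound 2 to compound 4 (0.38 log units; beyond the scatter), with a wide range. Compound 4 is expected to give about 250 nM, between 50 nM and 1500 nM.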

Compound 4, half-maximal inhibitory concentration: > 5000 nM
Compound 4 was reported as a limit; the forecaster's own chance of this, stated with the estimate: 0%; middle value at least 20-fold (1.30 log units) away from the limit.
By their numbers in this assay, from the lowest: compound 3; then compound 2; then compound 1. At a limit, above all of these: compound 4.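

Compound 4 stands only as a limit and not as a number: the limit of > 5000 nM in this assay, at which 1 of the 4 values shown sits.

Even so, the step is readable as an at least 47-fold higher number from compound 2 to compound 4 (1.67 log units; beyond the scatter) in this assay, and it shows that this position, which no earlier step had varied on its own, is sensitive to the group it carries. The 4-chlorophenyl that leaves holds a six-membered aromatic ring and 7 heavy atoms, whereas the tert-butyl that enters holds no ring and 4 heavy atoms, so among these two compounds only the ring-bearing group gives a measured value.

This single step cannot separate the loss of the ring from the loss of heavy atoms or of the chlorine. The compounds shown leave open whether a plain phenyl, a pyridyl or a cyclohexyl at this place would stand nearer to compound 2 or to compound 4.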